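This account rests on a few compounds, and the source may have more. Where it says the series, first, only, none or still open, it means among the compounds named here.

Measured in a physicochemical assay for lipophilicity; a lower number here means a more polar compound, a higher number a more lipophilic compound:
- Compound 1 `O=C(CN(C(=O)c1ccc(-n2ccnc2)cc1)C1CCCCC1)Nc1cc(F)cc(F)c1`: 2.7
- Compound 2 `O=C(CN(C(=O)c1ccc(-c2ccccn2)cc1)C1CCCCC1)Nc1cc(F)cc(F)c1`: 3.7
- Compound 3 `COc1ccc(C(=O)N(Cc2[nH]ncc2-c2ccccc2)C2CCCCC2)cc1`: 3.1

Compound 2, at 3.7, is the highest of the three, and both others lie lower by more than the scatter. Compound 4 `O=C(CN(CC1CCC1)C(=O)c1ccc(-c2ccccn2)cc1)Nc1cc(F)cc(F)c1` carries cyclobutylmethyl in place of cyclohexyl on an amide-type nitrogen. For the measured compounds named here, the only measured step, a number 1.00 log units higher from compound 1 to compound 2 (beyond the scatter), concerns an aromatic carbon, so it gives no direct measure for this change. Going by the values given here, no measured pair varies the group on that nitrogen. Both groups are carbon only, and the entering one is smaller, so only a small downward move is expected in this assay. The expected step is a number 0.30 log units lower from compound 2 to compound 4 (within the scatter). For compound 4 the estimated value is 3.4, with an expected range from 3 to 3.8.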

Compound 4, distribution coefficient: 3.5
Compound 4: the middle estimate sits 0.10 log units below what was measured, and the stated range covers the measured number.
By their numbers in this assay, from the lowest: compound 1; then compound 3; then compounds 4 and 2 (each within the scatter of the next).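

In this assay the amide-type nitrogen gets its first direct reading: cyclobutylmethyl in place of cyclohexyl gives a number 0.20 log units lower from compound 2 to compound 4 (within the scatter) and so stays within the scatter. In this pair, a four-membered carbon ring on a methylene link can stand where the six-membered carbon ring stood without a move beyond that scatter. Nothing measured accounts for the size of this step. Both groups compared at this nitrogen are carbon only. As far as these compounds go, how a group carrying an amine or a carboxylic acid would read there in this assay remains open.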